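Lipophilicity notes on a triazolyl-indole amine series

A few compounds are considered here, and "the series" means these few. Any claim that something is new, unique, unknown or untested is made for them only; others in the source may bear on it.

Measured so far in a physicochemical assay for lipophilicity; on this read-out higher numbers stand for higher lipophilicity and lower numbers for lower lipophilicity:
compound 1 `CC(C)Sc1nnc(-c2c(CNCCN3CCCC3)c3cc(F)ccc3n2C)n1-c1ccccc1` gives 4.99
compound 2 `CC(C)Sc1nnc(-c2c(CN3CCC(N4CCCC4)CC3)c3ccccc3n2C)n1-c1ccccc1` gives 5.16
compound 3 `COc1cccc(CNCc2c(-c3nnc(SC(C)C)n3-c3ccccc3)n(C)c3ccc(F)cc23)c1` gives 6.42

Compound 2 stands second highest of the three, within the scatter of compound 1 and well below compound 3. Compound 4 `CC(C)Sc1nnc(-c2c(CNCC3CC3)c3ccccc3n2C)n1-c1ccccc1` is not yet measured. The change is (cyclopropylmethyl)amino in place of 4-(pyrrolidin-1-yl)piperidin-1-yl on a saturated chain carbon bound to an aromatic carbon. Within the data shown here, the only measured step at a related position, a number 1.43 log units higher from compound 1 to compound 3 (beyond the scatter), was large but swapped in an aromatic ring and does not match this change; compound 1, which also carries a chain amine at that position, sits within the scatter of compound 2. The step here removes most of the carbon and one nitrogen, so a modest downward step is expected, a number 0.36 log units lower from compound 2 to compound 4 (beyond the scatter). Compound 4 is estimated at 4.8, in the range 4.2 to 5.4.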

Compound 4, partition coefficient: 5.24
Compound 4: the middle estimate sits 0.44 log units below what was measured, within the range that was stated.
By their numbers in this assay, from the lowest: compounds 1, 2 and 4 (each within the scatter of the next); then compound 3.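

Changing 4-(pyrrolidin-1-yl)piperidin-1-yl to (cyclopropylmethyl)amino on a saturated chain carbon bound to an aromatic carbon gives a number 0.08 log units higher from compound 2 to compound 4 (within the scatter) in this assay and so leaves the read-out unresolved. At this position, a large difference in heavy-atom count and the gain of a hydrogen-bond donor therefore come with no change beyond the scatter. No available evidence accounts for this result. Still open, going by these compounds, is whether a carboxylic acid or a morpholine on the same chain carbon would give a step beyond the scatter.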